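The compounds below may be only part of what the source reports. "The series", "measured", "known", "first", "only" and "open" are said of these compounds alone.

Measured in a functional assay on HeLa cells (Homo sapiens) for antiproliferative activity, with a stated time of 24 h; a lower number here means a stronger inhibitor, a higher number a weaker inhibitor:
- compound 1 `NC(=O)c1c(NC(=O)c2ccccc2Cl)sc2c1CCNC2`: 45000 nM
- compound 2 `Cc1ccccc1CN1CCc2c(sc(NC(=O)c3ccccc3Cl)c2C(N)=O)C1`: > 50000 nM, a limit of the assay
- compound 3 `NC(=O)c1c(NC(=O)c2ccccc2Cl)sc2c1CCN(Cc1ccccc1Cl)C2`: 27500 nM

In this assay compound 3 stands at 27500 nM, within the scatter of compound 1 at 45000 nM.

Compound 4 `NC(=O)c1c(NC(=O)c2ccccc2Cl)sc2c1CCN(Cc1ccc(Cl)cc1)C2` carries 4-chlorophenyl in place of 2-chlorophenyl on a saturated chain carbon bound to an amine nitrogen in a ring, which reads as 2-chlorobenzyl to 4-chlorobenzyl. Among the measured compounds shown here, no measured pair shows this swap. The nearest steps are small: a 1.6-fold lower number from compound 1 to compound 3 (0.21 log units; within the scatter), an at least 1.1-fold higher number from compound 1 to compound 2 (0.04 log units; that floor lies within the scatter) and an at least 1.8-fold lower number from compound 2 to compound 3 (0.25 log units; that floor lies within the scatter). No step beyond the scatter is therefore expected in this assay, and no direction can be assigned. The estimated step is a 1.0-fold lower number from compound 3 to compound 4 (0.01 log units; within the scatter). Compound 4 is expected at 27000 nM, with an estimated range of 12000 nM to 50000 nM.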

Compound 4, half-maximal inhibitory concentration: > 50000 nM
Compound 4: a limit, no number (the forecaster's own chance of this, stated with the estimate: 20%); at least 1.8-fold (0.26 log units) between middle value and limit.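

In this assay compound 4 gives > 50000 nM, a limit of the assay. The change from 2-chlorobenzyl to 4-chlorobenzyl on the amine nitrogen gives an at least 1.8-fold higher number from compound 3 to compound 4 (0.25 log units; that floor lies within the scatter), and adding 4-chlorobenzyl in place of hydrogen gives an at least 1.1-fold higher number from compound 1 to compound 4 (0.04 log units; that floor lies within the scatter), so neither step shows an effect of this position beyond the scatter. The step between the two limits, compound 2 and compound 4, cannot be read: the limit of > 50000 nM in this assay, at which 2 of the 4 values shown sit.

From the compounds shown here alone, it remains open whether any substituent on this nitrogen moves the value beyond the scatter. A 4-methoxybenzyl group or a longer chain ending in an amine could test this.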